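The source may hold more compounds than are shown below. What is called first, only, known or untested is meant among the compounds shown, and "the series" means these compounds.

Three compounds share one core and are compared in a functional assay on the whole organism (lung) for inhibition, with Cavia porcellus as the target; on this read-out higher numbers stand for an effect only at larger amounts of compound and lower numbers for an effect already at smaller amounts. Compound 1 `CCc1cc(C(=O)N[C@H](C)CCCc2cccnc2)ccc1-c1ccc(OC)c(OC)c1` gives 24 mg/kg, compound 2 `CCCCc1cc(C(=O)N[C@H](C)CCCc2cccnc2)ccc1-c1ccc(OC)c(OC)c1` gives 25 mg/kg, and compound 3 `COc1ccc(-c2ccc(C(=O)N[C@H](C)CCCc3cccnc3)cc2[N+](=O)[O-])cc1OC` gives 22 mg/kg. Compound 3 has the lowest of the three numbers, yet its steps to the others are small: a 1.1-fold lower number from compound 1 to compound 3 (0.04 log units; within the scatter) and a 1.1-fold lower number from compound 2 to compound 3 (0.06 log units; within the scatter), as is a 1.0-fold higher number from compound 1 to compound 2 (0.02 log units; within the scatter).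

Compound 4 `COc1ccc(-c2ccc(C(=O)NCCCCc3cccnc3)cc2[N+](=O)[O-])cc1OC` differs from compound 3 by hydrogen in place of methyl on a saturated chain carbon bound to an amide-type nitrogen and a saturated chain carbon. Going by the values given here, none of the measured steps touches this part of the molecule; each alters only the group on the aromatic carbon, and all fall within the scatter. Among the compounds with values here, with no step bearing on the chain change, compound 4 is expected to show no change at the digits printed from compound 3 to compound 4 (within the scatter) in this assay, giving an estimate of 22 mg/kg, with a range from 10 mg/kg to 48 mg/kg.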

Compound 4, dose for 50% inhibition: 39 mg/kg
Beside the measured number, compound 4's estimate is 1.8-fold (0.25 log units) below it; the measured number falls inside the stated range.
By their numbers in this assay, from the lowest: compounds 3, 1, 2 and 4 (each within the scatter of the next).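

Hydrogen in place of methyl on a saturated chain carbon bound to an amide-type nitrogen and a saturated chain carbon gives a 1.8-fold higher number from compound 3 to compound 4 (0.25 log units; within the scatter) in this assay. Going by these compounds alone, this is the first measured step at this position, since the earlier steps altered only the group on the aromatic carbon, and it shows that the read-out does not move beyond the scatter when this methyl goes. Nothing measured here accounts for the size of this step.

The compounds shown leave open whether the same change would read alike with ethyl or butyl in place of nitro. They also leave open what an ethyl group or an amine on this chain carbon would give.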